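Sulfonyl-linked ring swap on the diaryl core

This account rests on a few compounds, and the source may have more. Where it says the series, first, only, none or still open, it means among the compounds named here.

Measured compounds:
- compound 1, `Cc1ccc(C2CNN=C2S(=O)(=O)CC2=NCCS2)cc1`, 45.1%
- compound 2, `O=S(=O)(CC1=NCCS1)c1c(-c2ccccc2)noc1-c1ccccc1`, "not active" (no number reported), no number given

In a functional assay, tested at 100 ug/mL (a lower number here means a weaker effect, a higher number a stronger effect of the compound at the concentration tested), compound 1 gives 45.1%. Compound 2 carries a different core and stands apart: in this assay compound 2 is reported as "not active" (no number reported), and no single number exists for it, so its position can only be described as at the weak end of the read-out. For the measured compounds named here, no step between measured compounds is available, and nothing connects compound 1 to compound 2 in one place.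

Compound 3, `O=S(=O)(CC1=NCCO1)c1c(-c2ccccc2)noc1-c1ccccc1`, differs from compound 2 by a group of 5 heavy atoms (3 carbon, 1 nitrogen, 1 oxygen; one five-membered non-aromatic ring with 2 hetero atoms) in place of a group of 5 heavy atoms (3 carbon, 1 nitrogen, 1 sulfur; one five-membered non-aromatic ring with 2 hetero atoms), on a saturated chain carbon bound to a sulfonyl sulfur. The change keeps the same ring size and the same count of hetero atoms, exchanging one sulfur for one oxygen. With compound 2 reported as not active, the expected step in this assay from compound 2 to compound 3 is small and not clearly beyond the scatter, in either direction. Compound 3 is expected to give about 10% in this assay, within 0% to 35%.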

Compound 3, a percentage reported as activity, at one concentration (the size of the read-out at that concentration, not a potency): 60.1%
The estimate for compound 3 lay 50.1 percentage points below the measured number; measured number above the stated range.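

For the compounds shown here, no step from compound 2 to compound 3 can be read, as compound 2 has no single number. The compounds shown leave open how much of the read-out follows the exchange of sulfur for oxygen in the five-membered ring, and how compound 1 relates to either. No supporting measurement bears on this result.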